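The source may report more compounds than this note shows. Statements on the series, on what has been measured and on what is new or still open speak of the compounds shown alone.

Measured so far in an assay on Prostate gland for inhibition of steroid 5-alpha-reductase (Rattus norvegicus); on this read-out higher numbers stand for weaker inhibition and lower numbers for stronger inhibition:
compound 1 `C/C(=C\C(=O)Nc1ccccc1OCCCC(=O)O)c1ccc2c(ccn2C)c1` gives 780 nM
compound 2 `CCCCCCn1ccc2cc(/C(C)=C/C(=O)Nc3ccccc3OCCCC(=O)O)ccc21` gives 77 nM
compound 3 `CCCC(C)n1ccc2cc(/C(C)=C/C(=O)Nc3ccccc3OCCCC(=O)O)ccc21` gives 7.8 nM

Compound 3 has the lowest number of the three; the nearest is compound 2 a 9.9-fold lower number from compound 2 to compound 3 (0.99 log units; beyond the scatter) and the furthest is compound 1 a 100-fold lower number from compound 1 to compound 3 (2.00 log units; beyond the scatter). Compound 4 `CCCCC(CC)n1ccc2cc(/C(C)=C/C(=O)Nc3ccccc3OCCCC(=O)O)ccc21` differs from compound 3 in one place: 1-ethylpentyl in place of 1-methylbutyl on an aromatic nitrogen. For the measured compounds named here, two measured steps bear on this change in the group on the aromatic nitrogen: a 100-fold lower number from compound 1 to compound 3 (2.00 log units; beyond the scatter) was large, and a 9.9-fold lower number from compound 2 to compound 3 (0.99 log units; beyond the scatter) was modest. Both favour a chain of the kind present in compound 3, but nothing measured shows what a still larger chain does. A small further change in this assay, if any, is therefore expected for compound 4, estimated as a 1.3-fold lower number from compound 3 to compound 4 (0.11 log units; within the scatter). Compound 4 is estimated at 6 nM, with a range from 1.5 nM to 20 nM.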

Compound 4, half-maximal inhibitory concentration: 7.1 nM
Compound 4: the middle estimate sits 1.2-fold (0.07 log units) below what was measured, within the range that was stated.
By their numbers in this assay, from the lowest: compounds 4 and 3 (each within the scatter of the next); then compound 2; then compound 1.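

In this assay, the aromatic nitrogen accepts the larger 1-ethylpentyl group in place of 1-methylbutyl with no change beyond the scatter (a 1.1-fold lower number from compound 3 to compound 4 (0.04 log units; within the scatter)). The gain over the straight hexyl chain also persists with this larger branched group (an 11-fold lower number from compound 2 to compound 4 (1.04 log units; beyond the scatter)), and the gain over methyl remains large (a 110-fold lower number from compound 1 to compound 4 (2.04 log units; beyond the scatter)). No available evidence explains these results.

The compounds shown leave open how far the branched chain can grow before the number rises. They also leave open whether a cyclohexyl ring or a chain ending in an amine would serve equally well on this nitrogen.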